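The source may report more compounds than this note shows. Statements on the series, on what has been measured and on what is new or still open speak of the compounds shown alone.

Within the data shown here, compound 2 `CSc1cccc(C(=O)N2CCCC(C(=O)Nc3ccc(Cl)cc3)C2)c1` in an ADME assay on PC-3 cells (Homo sapiens) for cytotoxicity, read by WST assay, tested at 100 uM (a lower number here means less inhibition, a higher number more inhibition at the concentration tested (going by the name of the read-out)), gives 0%, level with compound 1 `C=Cc1cccc(C(=O)N2CCCC(C(=O)Nc3ccc(Cl)cc3)C2)c1`, which in this assay gives 0%; the only measured step, no change at the digits printed from compound 1 to compound 2 (within the scatter), lay within the scatter. Compound 3 `N#Cc1cccc(C(=O)N2CCCC(C(=O)Nc3ccc(Cl)cc3)C2)c1` differs from compound 2 by cyano in place of methylsulfanyl on an aromatic carbon. Among the measured compounds shown here, the one measured step bears only loosely on this change, and both values sit at the floor of the read-out, so for compound 3 no step beyond the scatter is expected in this assay; the expected step is a number 2 percentage points higher from compound 2 to compound 3 (within the scatter). Compound 3 is thus estimated at 2%, with a range from 0% to 15%.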

Compound 3, a percentage reported as inhibition, at one concentration (the size of the read-out at that concentration, not a potency): 0%
Compound 3: middle estimate off by 2 percentage points, on the high side; low and high end bracket the measured number.
By their numbers in this assay, from the lowest: compounds 1, 2 and 3 (each within the scatter of the next).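

Cyano in place of methylsulfanyl gives no change at the digits printed from compound 2 to compound 3 (within the scatter) in this assay at this place on the ring. Cyano in place of vinyl gives no change at the digits printed from compound 1 to compound 3 (within the scatter) in the same read-out. A nitrile therefore joins vinyl and methylsulfanyl on this aromatic carbon with no separation among the three. No evidence on hand accounts for this flat result.

Going by these compounds, whether an amine, a carboxylic acid or a longer chain on this carbon would lift the read-out off the floor remains open. So does the effect of changes elsewhere on the shared core.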